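The compounds below may be only part of what the source reports. "The series", "measured", "known", "first", "only" and "open" are said of these compounds alone.

Measured compounds:
- Compound 1, `Cc1nc(S(C)(=O)=O)ccc1Oc1ncnc(OC2CCN(C(=O)SC(C)C)CC2)c1F`: in a functional assay on isolated protein for inhibition of Glucose-dependent insulinotropic receptor (Rattus norvegicus), read by HTRF and cAMP accumulation (on this read-out higher numbers stand for larger maximal responses and lower numbers for smaller maximal responses), compound 1 gives 81%
- Compound 2, `Cc1nc(S(C)(=O)=O)ccc1Oc1ncnc(OC2CCN(C(=O)SC3CC3)CC2)c1F`: in this assay compound 2 gives 80%
- Compound 3, `Cc1nc(S(C)(=O)=O)ccc1Oc1ncnc(OC2CCN(C(=O)SC3(C)CC3)CC2)c1F`: in this assay compound 3 gives 77%

Compound 3 sits at the low end of the three numbers, but neither gap separates it from the others beyond the scatter: a number 3 percentage points lower from compound 2 to compound 3 (within the scatter) and a number 4 percentage points lower from compound 1 to compound 3 (within the scatter). The whole set of three lies inside one band of repeated-measurement noise.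

Compound 4 is `Cc1nc(S(C)(=O)=O)ccc1Oc1ncnc(OC2CCN(C(=O)SC3CCC3)CC2)c1F`. It differs from compound 3 only at the group carried on the sulfur next to the carbonyl carbon: cyclobutyl in place of 1-methylcyclopropyl on a sulfur.

All three measured steps bear on this change, since each of them also swaps the group on that sulfur. Each stayed within the scatter: a number 1 percentage points lower from compound 1 to compound 2 (within the scatter), a number 4 percentage points lower from compound 1 to compound 3 (within the scatter), a number 3 percentage points lower from compound 2 to compound 3 (within the scatter). Three different groups at this position have given the same maximal response within noise, so there is no basis in these data for a step beyond the scatter in this assay in either direction.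

Compound 4 is therefore expected to give 79% in this assay, within 70% to 88%. The expected step of a number 2 percentage points higher from compound 3 to compound 4 (within the scatter) is estimated to fall within the scatter.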

Compound 4, largest response reached (reported as efficacy), in percent of the reference or control that the assay uses: 81%
Estimate against measurement, compound 4: 2 percentage points below; the measured number falls inside the stated range.
By their numbers in this assay, from the lowest: compounds 3, 2, 1 and 4 (each within the scatter of the next).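

Cyclobutyl extends the range of groups on a sulfur whose other neighbour is the carbonyl carbon to a four-membered ring: in this assay, exchanging 1-methylcyclopropyl for cyclobutyl gives a number 4 percentage points higher from compound 3 to compound 4 (within the scatter), exchanging cyclopropyl gives a number 1 percentage points higher from compound 2 to compound 4 (within the scatter), and exchanging isopropyl gives no change at the digits printed from compound 1 to compound 4 (within the scatter). Among the compounds shown here, the pair of compound 3 and compound 4 adds a sharper test than the earlier steps, since the same atoms joined differently, as a three-membered ring with a methyl or as a four-membered ring, give maximal responses that cannot be told apart in this read-out. No separate data on these groups accompany the results, so this flat picture remains a description of four compounds and nothing more.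

The compounds shown leave open whether this flatness extends beyond small all-carbon groups on the sulfur, for example to a phenyl ring, a longer chain such as n-hexyl, or a group carrying an amine or a carboxylic acid. They also leave open how the maximal response would respond if an oxygen or a nitrogen took the place of the sulfur itself.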